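The compounds below may be only part of what the source reports. "The series", "measured", "known", "first", "only" and "open" are said of these compounds alone.

Three compounds sharing one core have numbers in a functional assay on MCF7 cells (Homo sapiens) for cytotoxicity, read by MTT assay, with a stated time of 72 h; a lower number here means a stronger inhibitor, a higher number a weaker inhibitor. There, compound 1 (`COc1cccc(/C=C2\CCC/C(=C\c3cccc(Cl)c3)C2=O)c1OC`) gives 12000 nM, compound 2 (`COc1cccc(/C=C2\CCC/C(=C\c3ccccc3Br)C2=O)c1OC`) gives 9700 nM, and compound 3 (`COc1cccc(/C=C2\CCC/C(=C\c3cccc(OC)c3OC)C2=O)c1`) gives 5900 nM. Compound 3 therefore stands close to the second of these, with a 1.6-fold lower number from compound 2 to compound 3 (0.22 log units; within the scatter), and apart from the first, with a 2.0-fold lower number from compound 1 to compound 3 (0.31 log units; beyond the scatter).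

Compound 4 (`COc1ccc(/C=C2\CCC/C(=C\c3cccc(OC)c3OC)C2=O)cc1`) has the same atoms as compound 3, joined differently: 4-methoxyphenyl in place of 3-methoxyphenyl on a double-bonded chain carbon bound to a double-bonded ring carbon, (4-methoxyphenyl in place of 3-methoxyphenyl on a double-bonded chain carbon bound to a double-bonded ring carbon). Among the measured compounds shown here, no measured step makes this exact exchange, so the evidence is indirect. The closest guide is the exchange at the same place that gives a 1.6-fold lower number from compound 2 to compound 3 (0.22 log units; within the scatter), and the replacement of 3-chlorophenyl by 2-bromophenyl gives a 1.2-fold lower number from compound 1 to compound 2 (0.09 log units; within the scatter). Both lie within the scatter. The largest step among these compounds, a 2.0-fold lower number from compound 1 to compound 3 (0.31 log units; beyond the scatter), is only modest, and it also involves a change of group rather than only a change of where the methoxy sits.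

In this assay, no step beyond the scatter is therefore expected, and neither direction is favoured, so the expected change is a 1.1-fold higher number from compound 3 to compound 4 (0.04 log units; within the scatter). For compound 4, the estimated value is 6500 nM, within an expected range of 2800 nM to 15000 nM.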

Compound 4, half-maximal inhibitory concentration: 18600 nM
Compound 4: middle estimate off by 2.9-fold (0.46 log units), on the low side, outside the stated range (above it).
By their numbers in this assay, from the lowest: compounds 3, 2, 1 and 4 (each within the scatter of the next, the first and the last beyond it).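

In this assay, exchanging 3-methoxyphenyl for 4-methoxyphenyl on a double-bonded chain carbon bound to a double-bonded ring carbon gives a 3.2-fold higher number from compound 3 to compound 4 (0.50 log units; beyond the scatter) and so shows that this place responds to where the methoxy stands, with no change in the atoms; every earlier step also changed the group, and the largest of them was a 2.0-fold lower number from compound 1 to compound 3 (0.31 log units; beyond the scatter) at this level of the series. Among the compounds shown here, the new compound does not separate from the other two, since a 1.9-fold higher number from compound 2 to compound 4 (0.28 log units; within the scatter) and a 1.6-fold higher number from compound 1 to compound 4 (0.19 log units; within the scatter) both remain within the scatter, which leaves compound 3 as the only compound set apart from compound 4. Nothing shown here offers an explanation for the effect of moving the methoxy.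

Going by these compounds, the finding rests on a single pair, so it remains open whether the exchange would have a similar size with a different group at the other end of the shared core. On these data alone, it is also open how a hydroxy group, an amine or a carboxylic acid would compare with the methoxy on this phenyl ring in this assay.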